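Regaining a Nitrogen-Only Group: Expected Rise in Inhibition

The compounds below may be only part of what the source reports. "The series", "measured", "known", "first", "only" and "open" are said of these compounds alone.

Going by the values given here, compound 2 `C/N=C(\S)NCCCCCCn1nc(-c2ccccc2)ccc1=O` gives 22.2% in a functional assay on the whole organism with Rattus norvegicus as the target, at a dose of 100 mg/kg (on this read-out lower numbers stand for less inhibition and higher numbers for more inhibition at the one dose given (going by the name of the read-out)), and stands lowest of the two numbers so far. Compound 1 `C/N=C(/NC#N)NCCCCCn1nc(-c2ccccc2)ccc1=O` gives 47.6% in this assay. Compound 3 `CN(C)/C(=N/CCCCCCn1nc(-c2ccccc2)ccc1=O)NC#N` is not yet measured; from compound 2 it differs by a group of 8 heavy atoms (4 carbon, 4 nitrogen; no ring) in place of a group of 5 heavy atoms (2 carbon, 2 nitrogen, 1 sulfur; no ring), on a saturated chain carbon, six bonds along the chain from an aromatic nitrogen. Among the compounds with values here, one measured step bears on this: a number 25.4 percentage points lower from compound 1 to compound 2 (beyond the scatter), where a sulfur-containing group replaced one of carbon and nitrogen only. Compound 3 reverses that kind of change, so an increase is expected, the estimated step being a number 17.8 percentage points higher from compound 2 to compound 3 (beyond the scatter). Compound 3 is expected to give 40%, between 20% and 60%.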

Compound 3, a percentage reported as inhibition, in the whole organism at one dose (the size of the read-out at that dose, not a potency): 58.4%
Compound 3: middle estimate off by 18.4 percentage points, on the low side, within the range that was stated.
By their numbers in this assay, from the lowest: compound 2; then compound 1; then compound 3.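

In this assay, putting the nitrile-bearing group in place of the sulfur-bearing group, on a saturated chain carbon, gives a number 36.2 percentage points higher from compound 2 to compound 3 (beyond the scatter), so the choice of group at this position can move the result by a large amount. The comparison with the earlier sulfur-free compound gives a number 10.8 percentage points higher from compound 1 to compound 3 (beyond the scatter), so that earlier level was not a ceiling. Nothing shown explains either step.

As far as these compounds go, how much of the rise over the earlier sulfur-free compound belongs to the chain and how much to the group stays open. So does how an amine or a carboxylic acid would compare at this position.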